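Compound 1 to compound 3: one added methyl

The source may report more compounds than this note shows. Statements on the series, on what has been measured and on what is new or still open speak of the compounds shown alone.

Of the compounds shown here, two have numbers so far. In a physicochemical assay for lipophilicity, at pH 7.4 (on this read-out higher numbers stand for higher lipophilicity and lower numbers for lower lipophilicity), compound 1 (`CC(C(=O)O)c1nn(Cc2cn3cc(OCC4CC4)c(Cl)cc3n2)c2ccccc2c1=O`) gives 2.44 as the lower of the two. Compound 2 (`O=C(O)Cn1nc(CC(=O)Nc2ccc(OC(F)(F)F)c(Cl)c2)c2ccccc2c1=O`) gives 2.92 and stands above it by a gap beyond the usual scatter. The two differ in more than one place, so that gap cannot be read as the size of any single change.

Compound 3 (`CC(C)(C(=O)O)c1nn(Cc2cn3cc(OCC4CC4)c(Cl)cc3n2)c2ccccc2c1=O`) keeps the core of compound 1 and changes one side chain, 1-carboxyethyl to 1-carboxy-1-methylethyl (methyl in place of hydrogen on a saturated chain carbon bound to an aromatic carbon, a carbonyl carbon and a saturated chain carbon), with methyl in place of hydrogen on a saturated chain carbon bound to an aromatic carbon, a carbonyl carbon and a saturated chain carbon. Within the data shown here, no measured pair isolates this change, so the expectation rests on the structural change alone. A modest rise in this assay is expected, and a step within the scatter would be no surprise. The step expected is a number 0.31 log units higher from compound 1 to compound 3 (beyond the scatter) and it would sit close to the edge of the scatter. Compound 3 is estimated in this assay at 2.75 with an expected range of 2.4 to 3.15 for the measurement.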

Compound 3, distribution coefficient: 2.95
The estimate for compound 3 lay 0.20 log units below the measured number; measured number inside the range.
By their numbers in this assay, from the lowest: compound 1; then compounds 2 and 3 (each within the scatter of the next).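

Among these compounds, the step from hydrogen to methyl, on a saturated chain carbon bound to an aromatic carbon, a carbonyl carbon and a saturated chain carbon, is the first change that can be read on its own. In this assay, turning 1-carboxyethyl into 1-carboxy-1-methylethyl on the core of compound 1 gives a number 0.51 log units higher from compound 1 to compound 3 (beyond the scatter), so a single added methyl at this position is enough to move the read-out past the usual scatter, which the earlier gap, spread over several differences, could not show. No measurement here bears on why this methyl moves the number by this amount.

From the compounds shown here alone, this is one step on one core, so whether the same replacement gives a step of similar size on the side chain of compound 2 remains open. Also open, going by these compounds, is how this assay responds at this same carbon to a longer chain such as ethyl, or to a hydroxyl or an amine in place of the added methyl, and whether the number then moves further, holds or turns back.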